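Lengthening the Carbonate Alkyl Chain by One Carbon

The source may report more compounds than this note shows. Statements on the series, on what has been measured and on what is new or still open speak of the compounds shown alone.

The three measured compounds share one core and differ only in the alkyl group of the carbonate. Compound 1 `CCCCCOC(=O)OCC(CO)CCn1cnc2cnc(N)nc21` carries a pentyl group, and in an ADME assay for pharmacokinetics, read by HPLC, in phosphate buffer, at 37 degrees C, at pH 6.0 (a higher number here means that the compound lasts longer, a lower number that the compound disappears faster), compound 1 gives 408 h. Compound 3 `COC(=O)OCC(CO)CCn1cnc2cnc(N)nc21` carries a methyl group, and in this assay compound 3 gives 432 h, so the two plain numbers sit together; the step of a 1.1-fold higher number from compound 1 to compound 3 (0.02 log units; within the scatter) lies within the scatter. Compound 2 `CC(C)OC(=O)OCC(CO)CCn1cnc2cnc(N)nc21` carries an isopropyl group, and in this assay compound 2 gives only a limit of the assay, > 4800 h. The step of an at least 11-fold lower number from compound 2 to compound 3 (1.04 log units; beyond the scatter) is large.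

Compound 4 `CCOC(=O)OCC(CO)CCn1cnc2cnc(N)nc21` is the ethyl carbonate. Compared with compound 3, the change is methyl in place of hydrogen on a saturated chain carbon bound to an oxygen next to a carbonyl group. Going by the values given here, two measured steps bear on it: a 1.1-fold higher number from compound 1 to compound 3 (0.02 log units; within the scatter), where a straight chain of different length made no difference beyond the scatter, and an at least 11-fold lower number from compound 2 to compound 3 (1.04 log units; beyond the scatter), where replacing the branched isopropyl by methyl gave a much lower number. Ethyl is unbranched, so compound 4 is expected to stay close to compound 3, with an expected step of a 1.2-fold higher number from compound 3 to compound 4 (0.06 log units; within the scatter). Compound 4 is therefore estimated at 500 h, between 250 h and 1200 h.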

Compound 4, half-life: 2690 h
Beside the measured number, compound 4's estimate is 5.4-fold (0.73 log units) below it; measured number above the stated range.
By their numbers in this assay, from the lowest: compounds 1 and 3 (each within the scatter of the next); then compound 4. At a limit, above all of these: compound 2.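

One added carbon at this place is enough to matter: methyl in place of hydrogen on the saturated chain carbon gives a 6.2-fold higher number from compound 3 to compound 4 (0.79 log units; beyond the scatter), and the comparison with the longer chain gives a 6.6-fold higher number from compound 1 to compound 4 (0.82 log units; beyond the scatter), so among these straight chains the number does not move in one direction with length, and the ethyl carbonate stands above both the methyl and the pentyl carbonates. Compound 2 gives no plain number, only a limit: the limit of > 4800 h in this assay, at which 1 of the 4 values shown sits. As a result, an at least 1.7-fold lower number from compound 2 to compound 4 (0.25 log units; that floor lies within the scatter) is only a floor, so the ethyl and isopropyl carbonates cannot be ordered, and a branched chain is not shown to be needed for a long half-life.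

Going by these compounds, how a propyl or a butyl carbonate would read remains open. So does whether a tert-butyl or a cyclopropyl group would follow the isopropyl carbonate.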